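The source may report more compounds than this note shows. Statements on the series, on what has been measured and on what is new or still open speak of the compounds shown alone.

In a functional assay on ECV-304 cells (Homo sapiens) for cytotoxicity (a higher number here means a weaker inhibitor, a lower number a stronger inhibitor), compound 1 `Cc1cccc(/C=C2\SC(=S)N(NS(=O)(=O)c3ccccc3)C2=O)c1` gives > 50000 nM, which is a limit and not a number. Compound 2 `COc1cccc(/C=C2\SC(=S)N(NS(=O)(=O)c3ccccc3)C2=O)c1` gives > 50000 nM, also only a limit. The measurements so far therefore amount to the limit of > 50000 nM in this assay, at which 2 of the 2 values shown sit. Compound 3 `O=C1/C(=C/c2ccc([N+](=O)[O-])cc2)SC(=S)N1NS(=O)(=O)c1ccccc1` carries one change from compound 2: 4-nitrophenyl in place of 3-methoxyphenyl on a double-bonded chain carbon bound to a double-bonded ring carbon. Among the measured compounds shown here, the only measured step that bears on this is a step that the two limits leave unreadable from compound 1 to compound 2, and it offers no size to carry over. The estimated a number no higher from compound 2 to compound 3 (the limit leaves the size open) is therefore expected to stay within the scatter, with no favoured direction. For compound 3 the expected value is 50000 nM, with an estimated range of 20000 nM to 100000 nM.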

Compound 3, half-maximal inhibitory concentration: > 50000 nM
Compound 3: a limit, no number (the forecaster's own chance of this, stated with the estimate: 70%); the middle value lies on the limit itself.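

Compound 3, like compound 1 and compound 2, yields only a limit in this assay, so no step among these compounds can be read. The compounds shown leave open how strongly any of them inhibits: the limit of > 50000 nM in this assay, at which 3 of the 3 values shown sit.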